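Triple-bond substituent swap from compound 2 to compound 3

The source may report more compounds than this note shows. Statements on the series, on what has been measured and on what is new or still open speak of the compounds shown alone.

In an ADME assay on WI-38 cells (Homo sapiens) for cytotoxicity, read by MTT assay, with a stated time of 3 days (on this read-out lower numbers stand for stronger inhibition and higher numbers for weaker inhibition), compound 1 `CCCCCC#Cc1cn(C/C=C/CN2C(=O)c3ccccc3C2=O)c(=O)[nH]c1=O` gives 40000 nM, and compound 2 `CCCCc1ccc(C#Cc2cn(C/C=C/CN3C(=O)c4ccccc4C3=O)c(=O)[nH]c2=O)cc1` gives 40000 nM, level with compound 1. Compound 3 `O=C1c2ccccc2C(=O)N1C/C=C/Cn1cc(C#CCCc2ccccc2)c(=O)[nH]c1=O` carries phenethyl in place of 4-butylphenyl on a triple-bonded carbon. Going by the values given here, one measured step bears on this change, since it also altered the group at that place: no change at the digits printed from compound 1 to compound 2 (within the scatter). Among the compounds with values here, with only that step as a guide, no change beyond the scatter is expected in this assay. The expected step is no change at the digits printed from compound 2 to compound 3 (within the scatter). For compound 3 the estimated value is 40000 nM, with an expected range of 20000 nM to 80000 nM.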

Compound 3, half-maximal inhibitory concentration: 31000 nM
Estimate against measurement, compound 3: 1.3-fold (0.11 log units) above; low and high end bracket the measured number.
By their numbers in this assay, from the lowest: compounds 3, 1 and 2 (each within the scatter of the next).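

In this assay, phenethyl in place of 4-butylphenyl gives a 1.3-fold lower number from compound 2 to compound 3 (0.11 log units; within the scatter) on the triple-bonded carbon, and phenyl in place of propyl on the saturated chain gives a 1.3-fold lower number from compound 1 to compound 3 (0.11 log units; within the scatter) in the same assay. The three groups now shown at this place, pentyl, 4-butylphenyl and phenethyl, all read alike, whether the chain ends in a phenyl ring or not. Nothing available explains this flat read-out.

From the compounds shown here alone, whether an amine or a carboxylic acid at this place would shift the number beyond the scatter remains open. So does the effect of changing the shared core.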